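A Fluoro Added to the Benzyl Group

The source may report more compounds than this note shows. Statements on the series, on what has been measured and on what is new or still open speak of the compounds shown alone.

In a functional assay on GBM1 cells (Homo sapiens) for antiproliferative activity, read by WST assay, with a stated time of 72 h (a lower number here means a stronger inhibitor, a higher number a weaker inhibitor), compound 1 (`O=C(Nc1ccc(Cl)c(Cl)c1)Nc1cc2ncncc2cc1OCc1ccccc1F`) gives 4100 nM, compound 2 (`O=C(Nc1ccccc1F)Nc1cc2ncncc2cc1OCc1ccccc1`) gives 6100 nM and compound 3 (`O=C(Nc1ccc(C(F)(F)F)cc1)Nc1cc2ncncc2cc1OCc1cccc(Cl)c1`) gives 3400 nM. Compound 2 therefore lies within the usual scatter of both others, and these numbers cannot rank the three. Compound 4 (`O=C(Nc1ccccc1F)Nc1cc2ncncc2cc1OCc1ccccc1F`) differs from compound 2 in one place: benzyl becomes 2-fluorobenzyl, with fluoro in place of hydrogen on an aromatic carbon. Going by the values given here, no measured pair shows this change alone. Compound 1, at 4100 nM, carries the same 2-fluorobenzyl group but differs elsewhere, so no step beyond the scatter is expected. The expected step is a 1.3-fold lower number from compound 2 to compound 4 (0.10 log units; within the scatter). The estimate for compound 4 is 4800 nM, within an expected range of 2200 nM to 10000 nM.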

Compound 4, half-maximal inhibitory concentration: 4200 nM
Estimate against measurement, compound 4: 1.1-fold (0.06 log units) above; the measured number falls inside the stated range.
By their numbers in this assay, from the lowest: compounds 3, 1, 4 and 2 (each within the scatter of the next).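

In this assay, going by these compounds alone, the first pair that differs only on the benzyl group gives a 1.5-fold lower number from compound 2 to compound 4 (0.16 log units; within the scatter) and so shows that fluoro in place of hydrogen at this place has no effect that can be told from the scatter. Replacing 3,4-dichlorophenyl with 2-fluorophenyl on the amide-type nitrogen while keeping 2-fluorobenzyl gives a 1.0-fold higher number from compound 1 to compound 4 (0.01 log units; within the scatter) and so cannot be told from the scatter either. No measurement here bears on why these numbers stay so close.

Still open, from the compounds shown here alone, is whether a different group on this benzyl ring, such as an amine or a carboxylic acid, would move the number beyond the scatter.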